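The source may hold more compounds than are shown below. What is called first, only, known or untested is meant among the compounds shown, and "the series" means these compounds.

Compound 1, `COc1cc(Nc2ncc(C(F)(F)F)c(N3Cc4cccc(N(C)S(C)(=O)=O)c4C3)n2)cc(OC)c1`, gives 24800 nM in a functional assay on A549 cells (Homo sapiens) for antiproliferative activity, read by spectrophotometry, with a stated time of 2 days; a higher number here means a weaker inhibitor of growth, a lower number a stronger inhibitor of growth. Compound 2, `CN(c1cccc2c1CN(c1nc(Nc3cc(Cl)cc(C(F)(F)F)c3)ncc1C(F)(F)F)C2)S(C)(=O)=O`, gives 6700 nM in this assay. Compound 3, `Cc1cc(F)ccc1Nc1ncc(C(F)(F)F)c(N2Cc3cccc(N(C)S(C)(=O)=O)c3C2)n1`, gives only a limit of the assay, > 30000 nM, in this assay.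

Compound 3 therefore stands at the limit of > 30000 nM in this assay, at which 1 of the 3 values shown sits, and carries no number of its own. Compound 4, `Cc1ccc(Nc2ncc(C(F)(F)F)c(N3Cc4cccc(N(C)S(C)(=O)=O)c4C3)n2)c(C)c1`, has not yet been measured; it differs from compound 3 by methyl in place of fluoro on an aromatic carbon.

Within the data shown here, the measured steps all swap the whole aryl group on the nitrogen on the aromatic ring, none of them alters a single substituent on that aryl as this change does. a 3.7-fold lower number from compound 1 to compound 2 (0.57 log units; beyond the scatter) and an at least 4.4-fold higher number from compound 2 to compound 3 (0.65 log units; beyond the scatter) mark compound 2 as the one with the lower number, while an at least 1.2-fold higher number from compound 1 to compound 3 (0.08 log units; that floor lies within the scatter) leaves compound 1 and compound 3 within the scatter of one another, with compound 3 at the limit. Nothing among these steps speaks to a methyl in place of a fluoro on an aromatic carbon, so the expectation is a step no larger than the scatter, with a real chance that compound 4 again lands at the limit.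

Compound 4 is expected to give 35000 nM in this assay, estimated to fall between 15000 nM and 90000 nM; this is expected to mean a step that the limit leaves unreadable from compound 3 to compound 4.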

Compound 4, concentration for 50% growth inhibition: 20700 nM
Compound 4: middle estimate off by 1.7-fold (0.23 log units), on the high side; measured number inside the range.
By their numbers in this assay, from the lowest: compound 2; then compounds 4 and 1 (each within the scatter of the next). At a limit, above all of these: compound 3.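

In this assay, among these compounds, methyl in place of fluoro on the aromatic carbon para to a large group is the first change to a single substituent on the aryl group, and it gives a step with a floor and not a full size (an at least 1.4-fold lower number from compound 3 to compound 4 (0.16 log units; that floor lies within the scatter)). Among the compounds shown here, compound 3 holds only a limit of the assay, so the real size of this step cannot be fixed, and it can be said only that the methyl compound returns a number: the limit of > 30000 nM in this assay, at which 1 of the 4 values shown sits. Set against the other aryl groups, the 2,4-dimethylphenyl group of compound 4 cannot be told apart from the 3,5-dimethoxyphenyl group (a 1.2-fold lower number from compound 1 to compound 4 (0.08 log units; within the scatter)), while the 3-chloro-5-(trifluoromethyl)phenyl group keeps its lower number (a 3.1-fold higher number from compound 2 to compound 4 (0.49 log units; beyond the scatter)).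

The compounds shown leave open what an amine, a hydroxyl or a carboxylic acid on this same aromatic carbon would give, since only fluoro and methyl are seen there. They also leave open whether methyl in place of fluoro would read the same way on an aryl group that lacks the neighbouring methyl group of compounds 3 and 4.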